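This account rests on a few compounds, and the source may have more. Where it says the series, first, only, none or still open, it means among the compounds named here.

Compound 1 `CCOC(=O)CCCCCOc1cccc(CN(C(=O)c2ccc(-c3ccco3)cc2)C(C)C)c1` and compound 2 `CCOC(=O)CCCCCOc1cccc(CN(C(=O)c2ccc(-c3cccc(OC(F)(F)F)c3)cc2)C(C)C)c1` share a core and differ in one place. Within the data shown here, the one measured step is a step that the two limits leave unreadable from compound 1 to compound 2. In an ADME assay on HepG2 cells (Homo sapiens) for cytotoxicity, read by CellTiter-Glo and resazurin assay, with a stated time of 72 h (on this read-out lower numbers stand for an effect already at smaller amounts and higher numbers for an effect only at larger amounts of compound), compound 1 gives > 26000 nM, which is a limit of the assay rather than a number. In this assay compound 2 also gives only a limit, > 26000 nM. Compound 2 thus sits at the limit of > 26000 nM in this assay, at which 2 of the 2 values shown sit, and nothing more about its position can be read from the numbers. Compound 3 `CCOC(=O)CCCCCOc1cccc(CN(C(=O)c2ccc(-c3cccc([N+](=O)[O-])c3)cc2)C(C)C)c1` remains to be measured in this assay and differs from compound 2 in one place, (nitro in place of trifluoromethoxy on an aromatic carbon). Among the measured compounds shown here, the single measured step has no readable size, so it cannot guide the direction or size of the change. Since every shown value rests at the same limit, compound 3 is expected to give 40000 nM, most likely again as a limit only, within 15000 nM to 150000 nM. The estimated step is a step that the limit leaves unreadable from compound 2 to compound 3.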

Compound 3, half-maximal effective concentration: > 26000 nM
Compound 3: a limit, no number (the forecaster's own chance of this, stated with the estimate: 80%); the middle value lies beyond the limit too.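

No step among compound 1, compound 2 and compound 3 can be read in this assay, as each value is a limit and not a number: the limit of > 26000 nM in this assay, at which 3 of the 3 values shown sit.

The compounds shown leave open how far past that limit each one lies, and whether exchanging these groups changes the read-out at all.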